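Swapping the aryl ring on the sulfur of compound 2

The source may report more compounds than this note shows. Statements on the series, on what has been measured and on what is new or still open speak of the compounds shown alone.

Compound 1 `OC[C@H]1O[C@@H](n2cnc3c(OCc4ccccc4)ncnc32)[C@H](O)[C@@H]1O` is the weaker of the two measured compounds: in an assay on isolated protein for binding affinity to Equilibrative nucleoside transporter 1 (Homo sapiens) (a lower number here means a stronger inhibitor, a higher number a weaker inhibitor), compound 1 gives 2090 nM. Compound 2 `OC[C@H]1O[C@@H](n2cnc3c(CSc4ccccc4F)ncnc32)[C@H](O)[C@@H]1O` carries a ((2-fluorophenyl)sulfanyl)methyl in place of benzyloxy on an aromatic carbon, and in this assay compound 2 gives 355 nM. Within the data shown here, that change is a 5.9-fold lower number from compound 1 to compound 2 (0.77 log units; beyond the scatter), so compound 2 stands at the lowest of the two numbers, with compound 1 its only neighbour at a clearly higher value.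

Compound 3 `OC[C@H]1O[C@@H](n2cnc3c(CSc4ccc(I)cc4)ncnc32)[C@H](O)[C@@H]1O` is not yet measured. It differs from compound 2 by 4-iodophenyl in place of 2-fluorophenyl on a sulfur. Among the measured compounds shown here, the one measured step concerns the link between the core and the ring, not the substituent on the ring itself, so it does not bear directly on this change; no measured pair shows what a 4-iodophenyl does against a 2-fluorophenyl here. The author therefore expects no step beyond the scatter, with the estimated change being a 1.1-fold lower number from compound 2 to compound 3 (0.05 log units; within the scatter). For compound 3 the expected value in this assay is 320 nM, in a range of 80 nM to 1300 nM.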

Compound 3, half-maximal inhibitory concentration: 69.2 nM
The estimate for compound 3 lay 4.6-fold (0.67 log units) above the measured number; measured number below the stated range.
By their numbers in this assay, from the lowest: compound 3; then compound 2; then compound 1.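

The ring on the sulfur proves to be a second point at which the number moves, not only the link to the core: in this assay, 4-iodophenyl in place of 2-fluorophenyl gives a 5.1-fold lower number from compound 2 to compound 3 (0.71 log units; beyond the scatter), beyond the scatter. The earlier compounds had shown a change only in the group as a whole, with benzyloxy giving way to ((2-fluorophenyl)sulfanyl)methyl. Read against the benzyloxy compound, the group carrying 4-iodophenyl gives a 30-fold lower number from compound 1 to compound 3 (1.48 log units; beyond the scatter), a large step that places compound 3 lowest of the three, although nothing available accounts for this gain.

From 2-fluorophenyl to 4-iodophenyl, both the halogen and its number in the name change, so the compounds shown cannot tell whether the iodine or its placement carries the step, and a 4-fluorophenyl or a 2-iodophenyl on the sulfur would separate the two. They also leave open how an unsubstituted phenyl, a 4-bromophenyl or a 4-methoxyphenyl would read in this assay, and so whether the trend follows the size of the halogen at all.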